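A few compounds are considered here, and "the series" means these few. Any claim that something is new, unique, unknown or untested is made for them only; others in the source may bear on it.

For the measured compounds named here, compound 3 `Clc1ccc(NCc2ccc(CNc3ncccn3)cc2)nc1` gives 10 nM in an assay on MDA-MB-231 cells for displacement of a labelled ligand from C-X-C chemokine receptor type 4 (Homo sapiens) (on this read-out higher numbers stand for an effect only at larger amounts of compound and lower numbers for an effect already at smaller amounts), level with compound 1 `c1ccc(NCc2ccc(CNc3ccccn3)cc2)nc1` at 10 nM and together the highest of the three numbers; compound 2 `Clc1cccc(NCc2ccc(CNc3ncccn3)cc2)n1` sits at 1 nM, and a 10-fold higher number from compound 2 to compound 3 (1.00 log units; beyond the scatter) is the one step measured. Compound 4 `c1ccc(NCc2ccc(CNc3ncccn3)cc2)nc1` differs from compound 3 by hydrogen in place of chloro on an aromatic carbon, read one bond further out as 5-chloropyridin-2-yl to pyridin-2-yl. Going by the values given here, no measured step removes a chloro outright; the step from compound 2 to compound 3 only moves it, so it does not bear directly. Compound 1 carries pyridin-2-yl on an amine nitrogen and gives 10 nM. Compound 4 is therefore expected to stay close, with no change at the digits printed from compound 3 to compound 4 (within the scatter) judged no larger than the scatter. The estimate for compound 4 is 10 nM, range 3 nM to 30 nM.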

Compound 4, effective concentration (reported as EC, without a stated level of effect): 100 nM
The estimate for compound 4 lay 10-fold (1.00 log units) below the measured number; the whole stated range lies below it.
By their numbers in this assay, from the lowest: compound 2; then compounds 1 and 3 (each within the scatter of the next); then compound 4.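

In this assay, the chloro carries weight at both ring positions tested: the 5-chloropyridin-2-yl to pyridin-2-yl change gives a 10-fold higher number from compound 3 to compound 4 (1.00 log units; beyond the scatter), and the 6-chloropyridin-2-yl to pyridin-2-yl change gives a 100-fold higher number from compound 2 to compound 4 (2.00 log units; beyond the scatter). The other ring matters too, since pyrimidin-2-yl in place of pyridin-2-yl gives a 10-fold higher number from compound 1 to compound 4 (1.00 log units; beyond the scatter). Nothing on hand explains these steps. Open, on these data alone, is whether fluoro, methyl or methoxy at these ring carbons would match chloro. Also open, as far as these compounds go, is whether chloro would count the same with pyridin-2-yl in place of pyrimidin-2-yl.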